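Swapping piperidine for piperazine on a thiocarbonyl carbon

The source may hold more compounds than are shown below. What is called first, only, known or untested is meant among the compounds shown, and "the series" means these compounds.

Compound 1 `CSC(=S)N/N=C1\CC2(CCCCC2)Oc2c1ccc1ccccc21` gives 3990 nM in a functional assay on A549 cells (Homo sapiens) for antiproliferative activity, read by MTT assay, with a stated time of 96 h; on this read-out lower numbers stand for stronger inhibition and higher numbers for weaker inhibition
Compound 2 `S=C(N/N=C1\CC2(CCCCC2)Oc2c1ccc1ccccc21)N1CCCCC1` gives 11400 nM in this assay

Of these two compounds, compound 2 has the higher number (11400 nM) and so the weaker inhibition. The next compound, compound 3 `S=C(N/N=C1\CC2(CCCCC2)Oc2c1ccc1ccccc21)N1CCNCC1`, keeps the shared core and carries piperazin-1-yl in place of piperidin-1-yl on a thiocarbonyl carbon. For the measured compounds named here, only one measured step bears on this change (a 2.9-fold higher number from compound 1 to compound 2 (0.46 log units; beyond the scatter)). It is modest, lies beyond the scatter and changed the group on the same thiocarbonyl carbon, but it replaced methylsulfanyl and not one six-membered non-aromatic ring with another. The data therefore give no firm direction, and in this assay the expected step is no larger than that one and probably within the scatter (a 1.3-fold lower number from compound 2 to compound 3 (0.10 log units; within the scatter)). Compound 3 is estimated at 9000 nM (expected range 3500 nM to 25000 nM).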

Compound 3, half-maximal inhibitory concentration: 12000 nM
Compound 3: the middle estimate sits 1.3-fold (0.12 log units) below what was measured; low and high end bracket the measured number.
By their numbers in this assay, from the lowest: compound 1; then compounds 2 and 3 (each within the scatter of the next).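

In this assay the swap of piperidin-1-yl for piperazin-1-yl on a thiocarbonyl carbon gives a 1.1-fold higher number from compound 2 to compound 3 (0.02 log units; within the scatter) and so shows no measurable difference between these two rings, although piperazin-1-yl carries a hydrogen-bond donor and acceptor that piperidin-1-yl lacks. Set against methylsulfanyl, piperazin-1-yl gives a 3.0-fold higher number from compound 1 to compound 3 (0.48 log units; beyond the scatter) and this step lies beyond the scatter, so both six-membered non-aromatic rings now stand apart from compound 1 by a similar margin. No supporting measurement is available to explain either step. Still open, as far as these compounds go, is whether an acetyl or methyl group on the ring nitrogen of piperazin-1-yl, or an open-chain amine such as dimethylamino on the thiocarbonyl carbon, would shift the number. Also open, from the compounds shown here alone, is whether a morpholine ring would fall with these two rings.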